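A few compounds are considered here, and "the series" means these few. Any claim that something is new, unique, unknown or untested is made for them only; others in the source may bear on it.

In an assay for inhibition of Neuropeptide Y receptor type 5 (Mus musculus) (on this read-out higher numbers stand for weaker inhibition and lower numbers for stronger inhibition), two compounds of the series have been measured. Compound 1 `COc1ccc(C(=O)c2cnc(Nc3cccc(C#N)c3)s2)cc1` gives 2230 nM, while compound 2 `Cc1ccccc1C(=O)c1cnc(Nc2cccc(C(F)(F)F)c2)s1` gives 63 nM, the lower of the two numbers, with compound 1 standing well apart from it, beyond the scatter. Compound 3 `O=C(c1cnc(Nc2cccc(C(F)(F)F)c2)s1)c1ccccc1C(F)(F)F` is not yet measured in this assay. It differs from compound 2 by trifluoromethyl in place of methyl on an aromatic carbon. Among the compounds with values here, no measured pair shows this exact change, so nothing here tells its size or direction. The step is expected to be small, a 1.3-fold higher number from compound 2 to compound 3 (0.10 log units; within the scatter), not clearly beyond the scatter. For compound 3 the estimate is 80 nM, expected to fall between 25 nM and 250 nM.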

Compound 3, half-maximal inhibitory concentration: 138 nM
Beside the measured number, compound 3's estimate is 1.7-fold (0.24 log units) below it; low and high end bracket the measured number.
By their numbers in this assay, from the lowest: compound 2; then compound 3; then compound 1.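

In this assay, the aromatic carbon ortho to a large group accepts trifluoromethyl in place of methyl, but the change is not neutral: it gives a 2.2-fold higher number from compound 2 to compound 3 (0.34 log units; beyond the scatter), a modest weakening of inhibition. Within the data shown here, this is the first single-place comparison, and it shows that this position responds to the change of group. Nothing available explains the step. As far as these compounds go, whether a chlorine atom, an amine or an ethyl group here would give a lower number remains open, as does whether this change would have the same effect on another member of the series.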